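Methoxy for Hydrogen on the Allyl Dichlorophenyl Core

A few compounds are considered here, and "the series" means these few. Any claim that something is new, unique, unknown or untested is made for them only; others in the source may bear on it.

Measured compounds:
compound 1 `C=CCn1c(=O)/c(=C\c2ccc(Cl)c(Cl)c2)[nH]c(=O)/c1=C\c1ccccc1`: "not active" (no number reported)
compound 2 `COc1ccccc1/C=c1\c(=O)[nH]/c(=C/c2ccccc2Cl)c(=O)n1C`: 110 nM
compound 3 `C=CCn1c(=O)/c(=C\c2ccccc2Cl)[nH]c(=O)/c1=C\c1ccccc1OC`: 2500 nM

In a functional assay on K562 cells (Homo sapiens) for cytotoxicity, read by CCK-8 assay, with a stated time of 72 h (on this read-out lower numbers stand for stronger inhibition and higher numbers for weaker inhibition), compound 1 is recorded as "not active" (no number reported) and no number is reported for it, so it cannot be placed on the scale of the other two. Compound 2 gives 110 nM and compound 3 gives 2500 nM in this assay. Going by the values given here, the single step between measured compounds is a 23-fold higher number from compound 2 to compound 3 (1.36 log units; beyond the scatter); it concerns the chain on the aromatic nitrogen, not the aryl ring, and so does not bear directly on the change at hand.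

Compound 4 `C=CCn1c(=O)/c(=C\c2ccc(Cl)c(Cl)c2)[nH]c(=O)/c1=C\c1ccccc1OC` arises from compound 1 by methoxy in place of hydrogen on an aromatic carbon. Among the compounds with values here, no measured pair isolates that change, so its size in this assay is unknown. Compound 3, which carries the allyl chain and the same 2-methoxyphenyl, sits at the weak end of the measured range, and compound 1, without the methoxy, gave no number at all. Compound 4 is therefore expected to remain weak, perhaps near or somewhat beyond compound 3, with a real chance that only a limit is reported. The estimate for compound 4 in this assay is 5000 nM, within 1500 nM to 20000 nM.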

Compound 4, half-maximal inhibitory concentration: "not active" (no number reported)
The entry for compound 4 holds no number, and the estimate cannot be compared.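

In this assay compound 1 gives "not active" (no number reported) and compound 4 gives "not active" (no number reported) so no step can be read between them. No further evidence bears on this result. The compounds shown leave open what methoxy in place of hydrogen does to the read-out on this dichlorophenyl-bearing allyl series.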